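Amino in place of methoxy on the shared core

The source may hold more compounds than are shown below. What is called first, only, known or untested is meant among the compounds shown, and "the series" means these compounds.

Three compounds with a shared core have been run in a functional assay on MT2 cells (Homo sapiens) for cytotoxicity; on this read-out higher numbers stand for lower toxicity in this test and lower numbers for higher toxicity in this test. Compound 1 `CC(C)=CCOc1cc(Nc2ncccn2)ccc1Cl` gives 2500 nM. Compound 3 `COc1ccnc(Nc2ccc(Cl)c(OCC=C(C)C)c2)n1` gives 9000 nM, the highest of the two numbers shown; its nearest neighbour is compound 1, the step being a 3.6-fold higher number from compound 1 to compound 3 (0.56 log units; beyond the scatter). Compound 2 `CC(C)=CCOc1cc(Nc2nccc(C)n2)ccc1Cl` is reported only as a limit of the assay, < 200 nM. The two further steps are an at least 12-fold lower number from compound 1 to compound 2 (1.09 log units; beyond the scatter) and an at least 45-fold higher number from compound 2 to compound 3 (1.65 log units; beyond the scatter); the second rests on (the limit of < 200 nM in this assay, at which 1 of the 3 values shown sits).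

Compound 4 `CC(C)=CCOc1cc(Nc2nccc(N)n2)ccc1Cl` has not yet been measured. It differs from compound 3 in one place: amino in place of methoxy on an aromatic carbon. Within the data shown here, no measured step involves an amino group, so the steps that bear on it are the two that exchange the group at this carbon of compound 3, a modest rise for methoxy in place of hydrogen and a large rise for methoxy in place of methyl, both quoted above. With methoxy leaving, some loss of the number is expected, but an amino group is not methyl, so for compound 4 a modest step downward is expected, a 1.8-fold lower number from compound 3 to compound 4 (0.26 log units; within the scatter). Compound 4 is therefore estimated at 5000 nM, with a range from 1500 nM to 20000 nM.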

Compound 4, half-maximal cytotoxic concentration: 500 nM
For compound 4 the middle estimate is 10-fold (1.00 log units) above the measured one, and the stated range ends above it.
By their numbers in this assay, from the lowest: compound 4; then compound 1; then compound 3. At a limit, below all of these: compound 2.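

Amino on this carbon of the shared core moves the number in the opposite direction from methoxy, and the two groups part sharply here (an 18-fold lower number from compound 3 to compound 4 (1.26 log units; beyond the scatter)). Set against hydrogen, amino also lowers the number (a 5.0-fold lower number from compound 1 to compound 4 (0.70 log units; beyond the scatter)), while methoxy alone among the groups shown raises it, so in this assay a lower number at this carbon is not tied to methyl. Compound 4 also sits apart from compound 2 (an at least 2.5-fold higher number from compound 2 to compound 4 (0.39 log units; beyond the scatter)), but that step rests on a limit: the limit of < 200 nM in this assay, at which 1 of the 4 values shown sits.

The compounds shown give no account of why amino and methoxy diverge so far at this carbon. On these data alone, whether a dimethylamino group, an ethoxy group or a chlorine here would follow amino or methoxy remains open.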